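Adding a Fluoro Group to a Chlorinated Chromone Scaffold

The source may hold more compounds than are shown below. What is called first, only, known or untested is meant among the compounds shown, and "the series" means these compounds.

Compound 2, with the structure `O=c1c(C2N=C(c3ccccc3)SS2)coc2cc(Cl)ccc12`, gives 76% in a functional assay on A549 cells (Homo sapiens) for inhibition, read by sulforhodamine B assay, with a stated time of 48 h, tested at 100 uM (a higher number here means more inhibition of growth at the concentration tested, a lower number less inhibition of growth), the higher of the two values recorded so far. Among the compounds with values here, the only comparison is compound 1, `O=c1c(C2N=C(c3ccccc3)SS2)coc2ccc(F)cc12`, which in this assay gives 55%, a result that falls clearly beyond the scatter of the method below compound 2; the two compounds carry different halogens at different places on the shared core, so no single step connects them.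

Compound 3, `O=c1c(C2N=C(c3ccccc3)SS2)coc2cc(Cl)c(F)cc12`, has not yet been measured. It differs from compound 2 by fluoro in place of hydrogen on an aromatic carbon, a change of one heavy atom on the fused aromatic ring. Within the data shown here, with no directly comparable step available, the expected step from compound 2 to compound 3 in this assay is a number 4 percentage points lower from compound 2 to compound 3 (within the scatter), that is, not beyond the usual scatter, with slightly more room on the downside than on the upside. Compound 3 is therefore estimated to give 72% in this assay, within a range of 55% to 88%.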

Compound 3, percent growth inhibition at one concentration: 57%
Compound 3: middle estimate off by 15 percentage points, on the high side, within the range that was stated.
By their numbers in this assay, from the lowest: compounds 1 and 3 (each within the scatter of the next); then compound 2.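

In this assay, fluoro in place of hydrogen on this aromatic carbon, ortho to a chloro group, is not a neutral change on the shared core: the data give a number 19 percentage points lower from compound 2 to compound 3 (beyond the scatter) and so show that this position responds to a single added atom. The reverse reading, chloro in place of hydrogen with the fluoro group already present, gives a number 2 percentage points higher from compound 1 to compound 3 (within the scatter), so the chloro group makes no difference beyond the scatter once fluoro is there. Nothing measured here gives a reason for this result.

On these data alone, whether a bromo, methoxy or amino group on this carbon would behave like fluoro remains open. So does the standing of the core with neither halogen, without which the separate contribution of each halogen cannot be read.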